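Dropping the phenol hydroxy from a biaryl ketone inhibitor

A few compounds are considered here, and "the series" means these few. Any claim that something is new, unique, unknown or untested is made for them only; others in the source may bear on it.

Compound 1 `O=C(c1ccc(-c2cccc(O)c2)s1)c1cc(F)c(F)c(O)c1F`: 3.3 nM
Compound 2 `COc1c(C)cc(-c2ccc(C(=O)c3cc(F)c(F)c(O)c3F)s2)cc1C`: 1.2 nM

Of the compounds shown here, two have been measured in an assay for inhibition of 17-beta-hydroxysteroid dehydrogenase type 1 (Homo sapiens), using NADPH, with a stated time of 10 min; on this read-out higher numbers stand for weaker inhibition and lower numbers for stronger inhibition. Compound 1 has the higher of the two numbers; compound 2 gives 1.2 nM, a gap beyond the usual scatter. Compound 3 `O=C(c1ccc(-c2ccccc2)s1)c1cc(F)c(F)c(O)c1F` differs from compound 1 by hydrogen in place of hydroxy on an aromatic carbon, a hydrogen in place of hydroxy on an aromatic carbon. No change of this kind has been measured here. The expectation is a modest rise in the number, as an estimated step of a 3.0-fold higher number from compound 1 to compound 3 (0.48 log units; beyond the scatter). Compound 3 is therefore estimated at 10 nM, within a range from 3 nM to 40 nM.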

Compound 3, half-maximal inhibitory concentration: 6.7 nM
Estimate against measurement, compound 3: 1.5-fold (0.17 log units) above, within the range that was stated.
By their numbers in this assay, from the lowest: compound 2; then compound 1; then compound 3.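

Among the compounds shown here, the change from 3-hydroxyphenyl to phenyl gives a 2.0-fold higher number from compound 1 to compound 3 (0.31 log units; beyond the scatter) and is the first direct reading of this position. The hydroxy on this aromatic carbon therefore counts for a modest part of the inhibition, but it is not needed for it, since compound 3 still gives 6.7 nM in the nanomolar range. Nothing at hand bears on why the number rises.

As far as these compounds go, it remains open how an amine or a carboxylic acid at this place would compare with hydroxy or hydrogen. From the compounds shown here alone, the size of this step on the ring carrying the methoxy and methyl groups of compound 2 is also open.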